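Silyl protection of the secondary alcohol in compound 2

The source may hold more compounds than are shown below. What is called first, only, known or untested is meant among the compounds shown, and "the series" means these compounds.

Two labdane-type furan compounds sharing one core have been measured. Compound 1 `C=C1[C@@H](O)C[C@H]2C(C)(C)CCC[C@]2(C)[C@H]1/C=C/c1ccoc1` gives 4.22 ug/mL in a functional assay on HUVEC cells (Homo sapiens) for inhibition, read by colorimetric assay and MTT assay; on this read-out lower numbers stand for stronger inhibition and higher numbers for weaker inhibition. Compound 2 `C=C1[C@H](O)C[C@H]2C(C)(C)CCC[C@]2(C)[C@H]1/C=C/c1ccoc1` gives 3.12 ug/mL in this assay. Going by the values given here, the one measured step, a 1.4-fold lower number from compound 1 to compound 2 (0.13 log units; within the scatter), follows from the fact that (the fact that compounds 1 and 2 differ only in the configuration as drawn), and it stays within the scatter, so the two numbers cannot be placed in order. Compound 2 carries the lower of the two numbers, with compound 1 nearest.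

Compound 3 `C=C1[C@H](O[Si](C)(C)C(C)(C)C)C[C@H]2C(C)(C)CCC[C@]2(C)[C@H]1/C=C/c1ccoc1` has not yet been measured. It differs from compound 2 by a group of 7 heavy atoms (6 carbon, 1 silicon; no ring) in place of a hydrogen atom, on an oxygen on a saturated carbon. Among the compounds with values here, no measured step bears on this kind of change: the only step on record is a change of configuration, not the replacement of a hydrogen on the oxygen. Within the data shown here, the expected direction in this assay therefore rests on no measured precedent, and the step of a 1.9-fold higher number from compound 2 to compound 3 (0.28 log units; within the scatter) is stated as an expectation only, with a wide range that allows the number to stay near that of compound 2 or to rise. Compound 3 is expected to give about 6 ug/mL in this assay, between 2 ug/mL and 20 ug/mL.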

Compound 3, half-maximal inhibitory concentration: > 50 ug/mL
Compound 3 ended at the assay's limit; the forecaster's own chance of this, stated with the estimate: 15%; middle value at least 8.3-fold (0.92 log units) away from the limit.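

In this assay, going by these compounds alone, a group of 7 heavy atoms (6 carbon, 1 silicon; no ring) in place of a hydrogen atom, on an oxygen on a saturated carbon, gives an at least 16-fold higher number from compound 2 to compound 3 (1.20 log units; beyond the scatter), and this is the only step printed as beyond the scatter. Within the data shown here, the earlier step, a 1.4-fold lower number from compound 1 to compound 2 (0.13 log units; within the scatter), showed only that the configuration change left the two numbers without an order, whereas this position proves sensitive to what sits on the oxygen. The value of compound 3 is a limit of the assay and not a number, so the step has a lower bound but no known full size: the limit of > 50 ug/mL in this assay, at which 1 of the 3 values shown sits.

The compounds shown cannot separate the loss of the hydrogen on this oxygen from the arrival of the entering group, since this one replacement changes both at once. As far as these compounds go, what a methyl or an acetyl group on the same oxygen would give remains open, as does whether the same replacement on the oxygen of compound 1 would have a comparable result.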